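The compounds below may be only part of what the source reports. "The series", "measured", "known", "first", "only" and "open" are said of these compounds alone.

Measured compounds:
- Compound 1, `COc1cc2c(Oc3ccc(NC(=O)c4nnn(-c5ccc(C)cc5)c4C(F)(F)F)cc3F)ccnc2cc1OCCCN1CCCC1`: 370 nM
- Compound 2, `COc1cc2c(Oc3ccc(NC(=O)c4nnn(-c5ccc(C)cc5)c4C(F)(F)F)cc3F)ccnc2cc1OCCCN1CCC(C)CC1`: 400 nM

Both compounds were tested in a functional assay on A549 cells (Homo sapiens) for cytotoxicity, read by MTT assay, with a stated time of 72 h; a lower number here means a stronger inhibitor, a higher number a weaker inhibitor. Among the measured compounds shown here, compound 2 has the highest of the two numbers, but its only neighbour is compound 1, and the two values lie within the scatter of each other, so they count as the same. For the measured compounds named here, the single measured step, a 1.1-fold higher number from compound 1 to compound 2 (0.03 log units; within the scatter), changes the saturated amine at the end of the chain, and it shows that this part of the molecule can be swapped without a change beyond the scatter.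

Compound 3, `COc1cc2c(Oc3ccc(NC(=O)c4nnn(-c5cccc(Br)c5)c4C(F)(F)F)cc3F)ccnc2cc1OCCCN1CCC(C)CC1`, has not yet been tested in this assay. It differs from compound 2 at a different position: 3-bromophenyl in place of 4-methylphenyl on an aromatic nitrogen. Going by the values given here, no measured step touches this aromatic ring, so the only step on hand says nothing directly about it. Without evidence either way, the most reasonable expectation is a number close to that of compound 2, with a wide range to allow for the unknown. Compound 3 is therefore expected to give about 400 nM, between 130 nM and 1300 nM. This estimate corresponds to an expected step of no change at the digits printed from compound 2 to compound 3 (within the scatter).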

Compound 3, half-maximal inhibitory concentration: 350 nM
Beside the measured number, compound 3's estimate is 1.1-fold (0.06 log units) above it; measured number inside the range.
By their numbers in this assay, from the lowest: compounds 3, 1 and 2 (each within the scatter of the next).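

Among the compounds shown here, until now, the only measured swap was in the saturated amine at the end of the chain, so nothing was known about the aromatic group on the other side of the molecule. In this assay, putting 3-bromophenyl in place of 4-methylphenyl on an aromatic nitrogen of the five-membered ring gives a 1.1-fold lower number from compound 2 to compound 3 (0.06 log units; within the scatter), so the two compounds count as the same. This single swap replaces a methyl group with a bromine and also moves the substituent to a different place on the phenyl ring, yet neither alteration, taken together with the other, produces a difference beyond the scatter; both groups have the same count of heavy atoms, so this says nothing yet about a much smaller or larger group here.

The compounds shown leave open how 3-methylphenyl or 4-bromophenyl would behave, which would separate the choice of substituent from its place on the ring, and whether a phenyl ring carrying a carboxylic acid or an amine would also match these numbers. Nothing measured alongside these compounds offers an explanation for this result.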